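The source may hold more compounds than are shown below. What is called first, only, known or untested is meant among the compounds shown, and "the series" means these compounds.

In an assay on cells for inhibition of ubiquitin carboxyl-terminal hydrolase 8 (Homo sapiens), read by fluorescence, with a stated time of 30 min (on this read-out lower numbers stand for stronger inhibition and higher numbers for weaker inhibition), compound 1 `COc1c(O)cc(O)c2c(=O)cc(-c3ccc(N4CCCNCC4)cc3)oc12` gives 31600 nM, and compound 2 `CC(C)Oc1c(O)cc(O)c2c(=O)cc(-c3ccc(N4CCCNCC4)cc3)oc12` gives 24500 nM. Of these two numbers, that of compound 2 is the smaller, but a 1.3-fold lower number from compound 1 to compound 2 (0.11 log units; within the scatter) lies within the scatter, so the two compounds are not told apart. Compound 3 `O=c1cc(-c2ccc(N3CCCNCC3)cc2)oc2c(OC3CCCCC3)c(O)cc(O)c12` differs from compound 2 by cyclohexyl in place of isopropyl on an oxygen on an aromatic ring. Going by the values given here, the one measured step that bears on this change is a 1.3-fold lower number from compound 1 to compound 2 (0.11 log units; within the scatter), which enlarged the group on the same oxygen without a shift beyond the scatter. Compound 3 is therefore expected to give 20000 nM, with a range from 8000 nM to 50000 nM, and a 1.2-fold lower number from compound 2 to compound 3 (0.09 log units; within the scatter) is expected to remain within the scatter.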

Compound 3, half-maximal inhibitory concentration: 16200 nM
The estimate for compound 3 lay 1.2-fold (0.09 log units) above the measured number; the measured number falls inside the stated range.
By their numbers in this assay, from the lowest: compounds 3, 2 and 1 (each within the scatter of the next).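

Cyclohexyl, a six-membered non-aromatic ring of carbon only, can stand on this oxygen without moving the number beyond the scatter, with a 1.5-fold lower number from compound 2 to compound 3 (0.18 log units; within the scatter) in this assay. Even the widest pair, with a 2.0-fold lower number from compound 1 to compound 3 (0.29 log units; within the scatter), remains within the scatter, so methyl, isopropyl and cyclohexyl on this oxygen are not told apart. Nothing available accounts for these numbers.

Still open, as far as these compounds go, is whether a longer chain ending in an amine or a carboxylic acid on this oxygen would shift the number beyond the scatter.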